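This account rests on a few compounds, and the source may have more. Where it says the series, first, only, none or still open, it means among the compounds named here.

Measured so far in a functional assay on MCF7 cells (Homo sapiens) for inhibition, read by sulforhodamine B assay, with a stated time of 48 h; a lower number here means a stronger inhibitor of growth, a higher number a weaker inhibitor of growth:
- compound 1 `Nc1cc(N)c2nc(-c3ccccc3)c(Oc3ccc(Cl)c(Cl)c3)nc2c1`: 70800 nM
- compound 2 `COc1cc(CNc2nc3cc(N)cc(N)c3nc2-c2ccccc2)cc(OC)c1OC`: a limit only
- compound 3 `COc1ccc(CNc2nc3cc(N)cc(N)c3nc2-c2ccccc2)cc1`: 26300 nM

Compound 1 stands at the highest of the two numbers shown in this assay. Compound 3 gives a number that is lower than that of compound 1 by a margin beyond the scatter. For compound 2 this assay reports only a limit, < 50200 nM, and not a number; see also (the limit of < 50200 nM in this assay, at which 1 of the 3 values shown sits). Among the compounds with values here, no pair of compounds differing in a single place has been measured, so no step size is known.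

Compound 4 `Nc1cc(N)c2nc(-c3ccccc3)c(Sc3ccc(F)cc3)nc2c1` has not been measured. It differs from compound 1 in one place: (4-fluorophenyl)sulfanyl in place of 3,4-dichlorophenoxy on an aromatic carbon. The shared core and the phenyl group are unchanged. Without a measured step of this kind, the expectation is for no change beyond the scatter in this assay, with the direction left open. The step from compound 1 to compound 4 is expected to be a 1.3-fold lower number from compound 1 to compound 4 (0.11 log units; within the scatter). Compound 4 is thus estimated at 55000 nM, within 18000 nM to 160000 nM.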

Compound 4, concentration for total growth inhibition: 63100 nM
Beside the measured number, compound 4's estimate is 1.1-fold (0.06 log units) below it, within the range that was stated.
By their numbers in this assay, from the lowest: compound 3; then compounds 4 and 1 (each within the scatter of the next).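

Within the data shown here, this is the first step measured: in this assay, the step is a 1.1-fold lower number from compound 1 to compound 4 (0.05 log units; within the scatter), so on this aromatic carbon, next to the ring nitrogen and ortho to a phenyl group, (4-fluorophenyl)sulfanyl in place of 3,4-dichlorophenoxy leaves the number within the scatter. The change swaps the oxygen link for sulfur and the chlorine substituents for fluorine in one move, so neither part can be read alone. Nothing measured on these compounds bears on this step, and no cause can be assigned to it.

Still open, going by these compounds, is whether a non-aromatic group on this carbon, such as morpholine or a carboxylic acid, moves the number beyond the scatter. Also open, on these data alone, is what a methyl group or a longer chain in place of the phenyl group would do to the number.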